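A few compounds are considered here, and "the series" means these few. Any claim that something is new, unique, unknown or untested is made for them only; others in the source may bear on it.

Compound 1 `CC/C=C\C/C=C\C/C=C\CCCCCCCc1cc(=O)c2c(O)cc(O)cc2o1`: 17500 nM
Compound 2 `CC/C=C\C/C=C\C/C=C\CCCCCCCc1cc(=O)c2c(O)cc(OCOC)cc2o1`: 17500 nM
Compound 3 `CC/C=C\C/C=C\C/C=C\CCCCCCCc1cc(=O)c2c(O)c(C)c(O)cc2o1`: 17500 nM

In a functional assay on MCF7 cells (Homo sapiens) for antiproliferative activity, read by MTT assay (on this read-out higher numbers stand for weaker inhibition and lower numbers for stronger inhibition), compound 1 gives 17500 nM, level with compounds 2 and 3 at the digits shown. Compound 4 `CCCCC/C=C\C/C=C\CCCCCCCc1cc(=O)c2c(O)cc(O)cc2o1` keeps the core of compound 1 and alters only the chain: butyl in place of but-1-en-1-yl on a saturated chain carbon bound to a double-bonded chain carbon.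

Two measured steps are available, no change at the digits printed from compound 1 to compound 2 (within the scatter) and no change at the digits printed from compound 1 to compound 3 (within the scatter). Among the measured compounds shown here, both are changes on the core, so neither tests the chain directly, and no measured compound varies the chain. They bear on this change only as a general sign of a flat series, and that is thin support. On that basis, no step beyond the scatter is expected in this assay, in either direction. The expected step is no change at the digits printed from compound 1 to compound 4 (within the scatter). The estimate for compound 4 is 17500 nM, with an expected range from 8000 nM to 35000 nM.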

Compound 4, half-maximal inhibitory concentration: 17500 nM
Beside the measured number, compound 4's estimate shows no gap at the digits printed, within the range that was stated.
By their numbers in this assay, from the lowest: compounds 1, 2, 3 and 4 (each within the scatter of the next).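

In this assay the chain now has a tested change of its own: butyl in place of but-1-en-1-yl on a saturated chain carbon bound to a double-bonded chain carbon gives no change at the digits printed from compound 1 to compound 4 (within the scatter), the first read on the chain rather than the core. Loss of this one chain double bond therefore leaves the read-out flat, and the flatness seen with the two core changes extends to this chain change, for these four compounds only. No available measurement accounts for this flat result.

Going by these compounds, whether a fully saturated chain, a shorter or longer chain, or an amine or carboxylic acid in place of the chain would shift the number remains open. Also open, on these data alone, is whether any change to the shared core or chain moves this assay beyond the scatter.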